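Swapping Methoxy for Trifluoromethyl on a Shared Core

The compounds below may be only part of what the source reports. "The series", "measured", "known", "first", "only" and "open" are said of these compounds alone.

Compound 1, with the structure `COc1ccc(-c2nc(C(=O)/C=C\Nc3ccc(Cl)cc3)c3ccccn23)cc1`, was tested in a functional assay on MDA-MB-231 cells (Homo sapiens) for cytotoxicity, read by MTT assay, with a stated time of 48 h; on this read-out higher numbers stand for weaker inhibition and lower numbers for stronger inhibition. In this assay compound 1 gives only the assay limit of > 30000 nM, not a measured number. A second compound, compound 2 with the structure `COc1ccc(N/C=C\C(=O)c2nc(-c3ccc(OC)cc3)n3ccccc23)cc1`, also reaches only the limit of > 30000 nM in this assay. The change from compound 1 to compound 2 is therefore a step that the two limits leave unreadable from compound 1 to compound 2. What is known about where both values sit is summed up in the limit of > 30000 nM in this assay, at which 2 of the 2 values shown sit.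

Compound 3, with the structure `O=C(/C=C\Nc1ccc(Cl)cc1)c1nc(-c2ccc(C(F)(F)F)cc2)n2ccccc12`, has not yet been measured. It differs from compound 1 by trifluoromethyl in place of methoxy on an aromatic carbon. Among the compounds with values here, no measured step here touches a trifluoromethyl group, so the only guide is that compound 1 itself shows no measurable inhibition. The expected step from compound 1 to compound 3 is therefore a number no higher from compound 1 to compound 3 (the limit leaves the size open), with a real chance that compound 3 again returns only a limit. The estimate for compound 3 in this assay is 30000 nM, expected to lie between 6000 nM and 150000 nM.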

Compound 3, half-maximal inhibitory concentration: 3840 nM
Compound 3: the middle estimate sits 7.8-fold (0.89 log units) above what was measured; measured number below the stated range.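

Swapping 4-methoxyphenyl for 4-(trifluoromethyl)phenyl gives, in this assay, an at least 7.8-fold lower number from compound 1 to compound 3 (0.89 log units; beyond the scatter), and this is the first step in the series that can be read, as the step between compound 1 and compound 2 cannot. It shows that the group at this place, on an aromatic carbon para to a large group, can move the compound from a limit of the assay to a measured number, and the size printed is only a minimum, as compound 1 gives no measured number to count from. Only compound 3 has so far left the limit, while the other two compounds remain at it: the limit of > 30000 nM in this assay, at which 2 of the 3 values shown sit.

The compounds shown leave open whether the gain comes from the presence of trifluoromethyl or simply from the absence of methoxy, and whether another group at this place, such as a nitrile, an amine or a carboxylic acid, would give a similar number. They also leave open whether the same swap would give a readable step on compound 2, which carries a second methoxy in place of the chloro.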